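Changing the amide aryl group in an anti-inflammatory series

This account rests on a few compounds, and the source may have more. Where it says the series, first, only, none or still open, it means among the compounds named here.

Two compounds have been measured in a functional assay on the whole organism for inhibition, with Rattus norvegicus as the target, read by cytopathic effect and paw edema, at a dose of 100 mg/kg by the oral route; on this read-out higher numbers stand for more inhibition at the one dose given (going by the name of the read-out) and lower numbers for less inhibition:

Compound 1, `O=C(Nc1ccc([N+](=O)[O-])cc1)c1c(O)c2cccnc2n(-c2ccccc2)c1=O`, gives -25.8%.
Compound 2, `Nc1ccc(NC(=O)c2c(O)c3cccnc3n(-c3ccccc3)c2=O)cc1`, gives 0%.

Both numbers sit near zero; compound 2 stands highest of the two, with compound 1 lower by a step, a number 25.8 percentage points higher from compound 1 to compound 2 (beyond the scatter), that lies beyond the scatter. Going by the values given here, the only structural step measured so far is this exchange of nitro for amino on the aromatic carbon.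

Compound 3, `Cc1cccc(NC(=O)c2c(O)c3cccnc3n(-c3ccccc3)c2=O)c1`, differs from compound 2 by 3-methylphenyl in place of 4-aminophenyl on an amide-type nitrogen. Among the compounds with values here, no measured step bears directly on this change, since the amino-to-nitro step touches a different part of the ring and its direction is not transferable. With both measured values near zero, compound 3 is expected to stay near zero as well, giving an expected step of a number 3 percentage points higher from compound 2 to compound 3 (within the scatter) within the scatter. The estimate for compound 3 in this assay is therefore 3%, with a range from -27% to 33%.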

Compound 3, a percentage reported as inhibition, in the whole organism at one dose (the size of the read-out at that dose, not a potency): 4.5%
Beside the measured number, compound 3's estimate is 1.5 percentage points below it; measured number inside the range.
By their numbers in this assay, from the lowest: compound 1; then compounds 2 and 3 (each within the scatter of the next).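

On the amide-type nitrogen, 3-methylphenyl in place of 4-aminophenyl gives a number 4.5 percentage points higher from compound 2 to compound 3 (within the scatter) in this assay so a ring carrying only carbon in this group reads the same as one carrying an amino group. The exchange starting from 4-nitrophenyl gives a number 30.3 percentage points higher from compound 1 to compound 3 (beyond the scatter) and this shows that among these three compounds, compound 1 alone stands apart, while compound 2 and compound 3 sit together near zero. No measurement on hand offers an explanation for this pattern.

Going by these compounds, whether a carboxylic acid or a methoxy group on this aromatic ring could lift the inhibition clearly above zero remains open. So does the question of whether a longer chain, such as ethyl or butyl, would read any differently from methyl.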